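The source may report more compounds than this note shows. Statements on the series, on what has been measured and on what is new or still open speak of the compounds shown alone.

Compound 1 `N#Cc1ccc(Nc2nc(NC3CCCC3)c3ccccc3n2)cc1` in a functional assay on KB cells (Homo sapiens) for antiproliferative activity, read by sulforhodamine B assay, with a stated time of 48 h (a higher number here means a weaker inhibitor of growth, a lower number a stronger inhibitor of growth), gives > 31300 nM, which is a limit of the assay and not a number.
Compound 2 `Nc1ccc(Nc2nc(NC3CCCC3)c3ccccc3n2)cc1` in this assay gives 17400 nM.

Compound 2 therefore holds the only number shown in this assay; the one further value is a limit, as the limit of > 31300 nM in this assay, at which 1 of the 2 values shown sits, records. The next compound, compound 3 `O=C(O)c1ccc(Nc2nc(NC3CCCC3)c3ccccc3n2)cc1`, differs from compound 2 by carboxy in place of amino on an aromatic carbon. Going by the values given here, only one measured step bears on this change: the step of an at least 1.7-fold lower number from compound 1 to compound 2 (0.25 log units; that floor lies within the scatter), which has a floor within the usual scatter, and it concerns a different group at the same place. With so little to go on, no step beyond the scatter is expected from compound 2 to compound 3, and a limit in this assay cannot be ruled out. Compound 3 is expected to give about 25000 nM, between 9000 nM and 70000 nM. That estimate implies a step of a 1.4-fold higher number from compound 2 to compound 3 (0.16 log units; within the scatter) from compound 2 to compound 3.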

Compound 3, concentration for 50% growth inhibition: 25200 nM
Estimate against measurement, compound 3: 1.0-fold (0.00 log units) below, within the range that was stated.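

At this place, on an aromatic carbon para to a large group, carboxy and amino are not told apart in this assay: the exchange gives a 1.4-fold higher number from compound 2 to compound 3 (0.16 log units; within the scatter). Carboxy in place of cyano gives an at least 1.2-fold lower number from compound 1 to compound 3 (0.09 log units; that floor lies within the scatter), so this comparison also shows no step beyond the scatter, and the three groups tried here do not yet separate the compounds. Compound 1 still stands at a limit of the assay, which is not a number: the limit of > 31300 nM in this assay, at which 1 of the 3 values shown sits.

As far as these compounds go, it remains open whether another group at this place, such as a methoxy, a hydroxyl or a longer aminoalkyl chain, would give a step beyond the scatter. From the compounds shown here alone, it is also open whether carboxy and amino would stay this close if the cyclopentyl group on the other amine were replaced by a phenyl ring or a shorter alkyl chain.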